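Reversing the enone on the shared core: from compound 2 to compound 4

The source may hold more compounds than are shown below. What is called first, only, known or untested is meant among the compounds shown, and "the series" means these compounds.

Measured compounds:
compound 1 `COc1ccc(-c2cc(/C=C/C(=O)c3cc(OC)c(OC)c(OC)c3)nc3cc(-c4ccccc4)nn23)cc1OC`, 4700 nM
compound 2 `COc1ccc(-c2cc(/C=C/C(=O)c3ccc(Cl)cc3)nc3cc(-c4ccccc4)nn23)cc1OC`, 17100 nM
compound 3 `COc1cc(-c2cc(/C=C/C(=O)c3ccc(Cl)cc3)nc3cc(-c4ccccc4)nn23)cc(OC)c1OC`, 32500 nM

In a functional assay on MDA-MB-231 cells (Homo sapiens) for antiproliferative activity, read by MTT assay, with a stated time of 24 h (a higher number here means a weaker inhibitor, a lower number a stronger inhibitor), compound 2 gives the second highest of the three numbers. Compound 3 sits nearest, with a 1.9-fold higher number from compound 2 to compound 3 (0.28 log units; within the scatter), and compound 1 furthest, with a 3.6-fold higher number from compound 1 to compound 2 (0.56 log units; beyond the scatter). Compound 4 `COc1ccc(-c2cc(C(=O)/C=C/c3ccc(C)cc3)nc3cc(-c4ccccc4)nn23)cc1OC` carries the change ((2-(4-methylphenyl)ethenyl)carbonyl in place of 2-((4-chlorophenyl)carbonyl)ethenyl on an aromatic carbon). For the measured compounds named here, no measured step reverses the enone in this way; the only step on that side of the core is the aryl swap from compound 1 to compound 2, which was modest. The account therefore expects a step from compound 2 to compound 4 of a 1.1-fold lower number from compound 2 to compound 4 (0.06 log units; within the scatter) in this assay, within the scatter. Compound 4 is estimated at 15000 nM, in the range 5000 nM to 50000 nM.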

Compound 4, half-maximal inhibitory concentration: 22600 nM
Compound 4: middle estimate off by 1.5-fold (0.18 log units), on the low side, and the stated range covers the measured number.
By their numbers in this assay, from the lowest: compound 1; then compounds 2, 4 and 3 (each within the scatter of the next).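

In this assay the carbonyl and ethenyl of this arm change order on the aromatic carbon, 4-methylphenyl replaces 4-chlorophenyl, and the outcome stays within the scatter, with a 1.3-fold higher number from compound 2 to compound 4 (0.12 log units; within the scatter). The earlier compounds shown here varied only the aryl groups, whereas this step shows that the arm's orientation can differ with no change beyond the scatter. No supporting data here explain this result.

The compounds shown do not separate the reversal from the aryl swap. On these data alone, how a reversed arm carrying 4-chlorophenyl, or an amine on that ring, would read remains open.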